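Swapping the Carbonyl Substituent of Compound 3

The compounds below may be only part of what the source reports. "The series", "measured", "known", "first", "only" and "open" are said of these compounds alone.

Compound 3 `O=C(CN(Cc1ccccc1)Cc1ccc2ccccc2c1)OCCO` carries a (2-hydroxyethoxy)carbonyl on a saturated chain carbon bound to an amine nitrogen. In an assay on HEK293 cells for binding affinity to Substance-K receptor (Rattus norvegicus), read by FRET, tested at 10 uM (on this read-out lower numbers stand for less inhibition and higher numbers for more inhibition at the one concentration tested (going by the name of the read-out)), compound 3 gives 0%. Compound 1 `N#CCN(Cc1ccccc1)Cc1ccc2ccccc2c1` bears a cyano at that carbon, and in this assay compound 1 gives 0%. Compound 2 `N#CCCCN(Cc1ccccc1)Cc1ccc2ccccc2c1` bears a 2-cyanoethyl there, and in this assay compound 2 gives 0%. Compound 3 thus stands level with both neighbours: no change at the digits printed from compound 1 to compound 3 (within the scatter) and no change at the digits printed from compound 2 to compound 3 (within the scatter), and in the same way no change at the digits printed from compound 1 to compound 2 (within the scatter).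

Compound 4 `CN1CCN(C(=O)CN(Cc2ccccc2)Cc2ccc3ccccc3c2)CC1` differs from compound 3 at the carbonyl carbon: 4-methylpiperazin-1-yl in place of 2-hydroxyethoxy on a carbonyl carbon. Within the data shown here, none of the measured steps touches the carbonyl carbon; the three steps that exist all exchange the group on the saturated chain carbon bound to the amine nitrogen, and each of them lies within the scatter. What the data show is a shared core that has given no inhibition in this assay under three different substituents, with nothing to suggest that a fourth would behave otherwise. The step is therefore expected to be no change at the digits printed from compound 3 to compound 4 (within the scatter), not beyond the scatter. Compound 4 is expected to give 0% in this assay, with a likely range from -10% to 12%.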

Compound 4, a percentage reported as inhibition, at one concentration (the size of the read-out at that concentration, not a potency): 0%
Estimate against measurement, compound 4: no gap at the digits printed, within the range that was stated.
By their numbers in this assay, from the lowest: compounds 1, 2, 3 and 4 (each within the scatter of the next).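

In this assay, among these compounds, this is the first step at the carbonyl carbon rather than on the saturated chain carbon, and replacing 2-hydroxyethoxy with 4-methylpiperazin-1-yl gives no change at the digits printed from compound 3 to compound 4 (within the scatter). The exchange brings in one six-membered non-aromatic ring with 2 hetero atoms and removes the hydrogen-bond donor of the leaving group, yet the read-out stays flat, and the two wider comparisons agree: no change at the digits printed from compound 2 to compound 4 (within the scatter) and no change at the digits printed from compound 1 to compound 4 (within the scatter). No measurement is available that would explain this flat result.

Since all four compounds give the same reading, these data cannot separate the effect of one substituent from another, and they do not show whether any change at this carbonyl carbon can produce inhibition in this assay on the shared core. Going by these compounds, a carboxylic acid, a primary amide or a longer chain bearing a terminal amine at the carbonyl carbon remains open, as does whether a group of this kind would lift compound 4's core above the level seen here.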